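A few compounds are considered here, and "the series" means these few. Any claim that something is new, unique, unknown or untested is made for them only; others in the source may bear on it.

Compound 1 `CN(C)CCCNc1nc(-c2ccc(NC(=O)Nc3ccccc3Cl)cc2)nc2ccsc12`: 430 nM
Compound 2 `CN(C)CCCNc1nc(-c2ccc(NC(=O)Nc3ccc(Cl)cc3Cl)cc2)nc2ccsc12`: 1020 nM
Compound 3 `CCN(CC)CCCNc1nc(-c2ccc(NC(=O)Nc3ccccc3Cl)cc2)nc2c(Cl)c(Cl)sc12`: 330 nM

All three numbers come from a functional assay on NCI-H460 cells (Homo sapiens) for cytotoxicity, read by MTT assay, with a stated time of 72 h; a higher number here means a weaker inhibitor, a lower number a stronger inhibitor. Compound 1 and compound 2 share one core; compound 3 carries a different core, and the difference between the two cores is not broken down here. Compound 2 arises from compound 1 by a single change, (chloro in place of hydrogen on an aromatic carbon), and that step reads a 2.4-fold higher number from compound 1 to compound 2 (0.38 log units; beyond the scatter). The numbers for compound 3 and compound 1 lie within the usual scatter of each other, so nothing can be said about which is the stronger; the gap between compound 3 and compound 2 lies beyond the scatter.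

Compound 4 `CCN(CC)CCCNc1nc(-c2ccc(NC(=O)Nc3ccc(Cl)cc3Cl)cc2)nc2c(Cl)c(Cl)sc12` has not yet been measured. It stands to compound 3 as compound 2 stands to compound 1: the change is chloro in place of hydrogen on an aromatic carbon, the same change at the same place, only on the other core. Because the earlier step of a 2.4-fold higher number from compound 1 to compound 2 (0.38 log units; beyond the scatter) was a modest weakening, a step of about the same size is expected here, a 2.4-fold higher number from compound 3 to compound 4 (0.38 log units; beyond the scatter); this rests on a single measured pair and on the assumption that the other core does not alter the effect, so it is held loosely. For compound 4 the estimate in this assay is therefore 800 nM, with a plausible range from 400 nM to 1700 nM.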

Compound 4, half-maximal inhibitory concentration: 1170 nM
Compound 4: middle estimate off by 1.5-fold (0.17 log units), on the low side; the range from low to high includes it.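

On the core of compound 3, turning the 2-chlorophenyl into the 2,4-dichlorophenyl weakens the compound in this assay, with a 3.5-fold higher number from compound 3 to compound 4 (0.55 log units; beyond the scatter), so the added chloro moves the number the same way here as it did on the core of compound 1. The two steps can be set side by side, and their sizes cannot be told apart: the same change on two cores in this assay, a 2.4-fold higher number (0.38 log units; beyond the scatter) from compound 1 to compound 2 and a 3.5-fold higher number (0.55 log units; beyond the scatter) from compound 3 to compound 4, 1.5-fold (0.17 log units) apart, within the scatter of two such steps. For the compounds shown here, this shows that, across these two cores, the change carried over in direction and, within the scatter, in size, which makes one core a fair guide to the other for this particular change; it does not show that the same would hold on any further core, since it rests on only two pairs in one cell line, and it offers no explanation of the weakening.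

From the compounds shown here alone, what remains open is whether the weakening is specific to chloro or would also follow from another group on the same aromatic carbon, such as fluoro, methyl or methoxy. The compounds shown also leave open how this change would behave with a longer chain leading to the amine, or with a morpholine in place of the dialkylamino end.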